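Aryl exchange on the shared core: expectation for compound 3

The source may hold more compounds than are shown below. What is called first, only, known or untested is meant among the compounds shown, and "the series" means these compounds.

Measured so far in a functional assay on Jurkat cells for inhibition of nuclear factor NF-kappa-B complex (Homo sapiens); on this read-out lower numbers stand for stronger inhibition and higher numbers for weaker inhibition:
- compound 1 `CCOC(=O)c1cnc(-c2cc(Cl)nc(Cl)c2)nc1NN1C(=O)C=C(C)C1=O`: 2000 nM
- compound 2 `CCOC(=O)c1cnc(-n2nc(C)cc2C)nc1NN1C(=O)C=C(C)C1=O`: 10000 nM
- compound 3 `CCOC(=O)c1cnc(-c2ccc(Cl)cc2)nc1NN1C(=O)C=C(C)C1=O`: not yet measured

Compound 2 stands at the highest of the two numbers, with compound 1 giving the lower one. Among the measured compounds shown here, the only measured step is a 5.0-fold higher number from compound 1 to compound 2 (0.70 log units; beyond the scatter), where a five-membered aromatic ring with two hetero atoms replaced a six-membered carbon ring carrying chlorine on the aromatic carbon between two ring nitrogen atoms.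

The change now considered is 4-chlorophenyl in place of 3,5-dimethyl-1H-pyrazol-1-yl on an aromatic carbon. It reverses the direction of that single step: a six-membered aromatic ring of carbon only with one chlorine returns at the same place. On that basis the number for compound 3 is expected to fall, with a 3.3-fold lower number from compound 2 to compound 3 (0.52 log units; beyond the scatter), landing closer to compound 1 than to compound 2. For the measured compounds named here, only one step informs this, so the range is kept wide. The estimate for compound 3 in this assay is 3000 nM, between 1000 nM and 10000 nM.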

Compound 3, half-maximal inhibitory concentration: 300 nM
Beside the measured number, compound 3's estimate is 10-fold (1.00 log units) above it; the measured number lies below the stated range.
By their numbers in this assay, from the lowest: compound 3; then compound 1; then compound 2.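

In this assay, the aromatic carbon between two ring nitrogen atoms responds to the exchanged group over a wider span than the first pair showed: 4-chlorophenyl in place of 3,5-dimethyl-1H-pyrazol-1-yl gives a 33-fold lower number from compound 2 to compound 3 (1.52 log units; beyond the scatter). The same group also improves on 2,6-dichloropyridin-4-yl, with a 6.7-fold lower number from compound 1 to compound 3 (0.82 log units; beyond the scatter), so compound 3 is the most potent of the three. Both six-membered rings give lower numbers than the five-membered ring, and the ring of carbon only gives the lowest, though no data available here explain this order.

Whether the chlorine contributes remains open, since the compounds shown do not separate it from the ring; a plain phenyl, or a methoxy or amine group in its place, would test this. Also open, on these data alone, is whether the gain holds if the ethoxycarbonyl group becomes a carboxylic acid.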